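Swapping a trifluoromethyl-bearing chain for an oxetane ring

The source may hold more compounds than are shown below. What is called first, only, known or untested is meant among the compounds shown, and "the series" means these compounds.

Of the compounds shown here, three sharing one core have been measured in a functional assay on isolated protein for inhibition of Glucose-dependent insulinotropic receptor (Rattus norvegicus), read by HTRF and cAMP accumulation; on this read-out lower numbers stand for an effect already at smaller amounts and higher numbers for an effect only at larger amounts of compound. Compound 1 `Cc1nc(S(C)(=O)=O)ccc1Oc1ncnc(OC2CCN(C(=O)OC3CCC3)CC2)c1F` gives 167 nM. Compound 2 `Cc1nc(S(C)(=O)=O)ccc1Oc1ncnc(OC2CCN(C(=O)OC(C)F)CC2)c1F` gives 315 nM. Compound 3 `Cc1nc(S(C)(=O)=O)ccc1Oc1ncnc(OC2CCN(C(=O)O[C@@H](C)C(F)(F)F)CC2)c1F` gives 109 nM, the lowest of the three numbers, though its gap to compound 1 is within the scatter, while its gap to compound 2 is beyond it.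

Compound 4 `Cc1nc(S(C)(=O)=O)ccc1Oc1ncnc(OC2CCN(C(=O)OC3(C(F)(F)F)COC3)CC2)c1F` differs from compound 3 in one place: 3-(trifluoromethyl)oxetan-3-yl in place of 1-(trifluoromethyl)ethyl on an oxygen next to a carbonyl group.

Among the compounds with values here, two measured steps bear on this change. Going from compound 1 to compound 3, a 1.5-fold lower number from compound 1 to compound 3 (0.19 log units; within the scatter), and from compound 2 to compound 3, a 2.9-fold lower number from compound 2 to compound 3 (0.46 log units; beyond the scatter). Compound 1 carries a ring at the same oxygen, and its number sits within the scatter of compound 3, so adding a ring here has not moved the number much. The expected step in this assay from compound 3 to compound 4 is therefore small, a 1.5-fold higher number from compound 3 to compound 4 (0.17 log units; within the scatter), with no clear direction. Compound 4 is estimated at 160 nM, within a range of 60 nM to 420 nM.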

Compound 4, half-maximal effective concentration: 342 nM
For compound 4 the middle estimate is 2.1-fold (0.33 log units) below the measured one; low and high end bracket the measured number.
By their numbers in this assay, from the lowest: compounds 3, 1, 2 and 4 (each within the scatter of the next, the first and the last beyond it).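

In this assay, within the data shown here, the 3-(trifluoromethyl)oxetan-3-yl group is the first change at this position to move the number clearly upward from the best of the earlier compounds, with a 3.1-fold higher number from compound 3 to compound 4 (0.50 log units; beyond the scatter). The same group also gives a 2.0-fold higher number from compound 1 to compound 4 (0.31 log units; beyond the scatter), so the earlier reading that a ring here changes little holds for cyclobutyl but does not extend to every four-membered ring. Against 1-fluoroethyl the step is a 1.1-fold higher number from compound 2 to compound 4 (0.04 log units; within the scatter), so these two groups cannot be told apart in this assay.

Nothing measured here explains why the number rises. The compounds shown cannot separate the contribution of the ring oxygen from that of the trifluoromethyl group, and they leave open how a plain oxetan-3-yl or a tert-butyl group would read at this oxygen.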